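The source may hold more compounds than are shown below. What is called first, only, known or untested is meant among the compounds shown, and "the series" means these compounds.

In an assay on HeLa cells for inhibition of sphingosine-1-phosphate transporter SPNS2 (Mus musculus), read by LC-MS, tested at 2 uM (a higher number here means more inhibition at the concentration tested (going by the name of the read-out), a lower number less inhibition), compound 1 `CCCCCCCCCCc1ccc(-c2noc(CCCNC)n2)cc1` gives 45%, compound 2 `CCCCCCCCCCc1ccc(-c2noc(CC3CNC3)n2)cc1` gives 63% and compound 3 `CCCCCCCCCCc1ccc(-c2noc(CC3CCNC3)n2)cc1` gives 44%. Compound 2 has the highest number of the three, since a number 18 percentage points higher from compound 1 to compound 2 (beyond the scatter) and a number 19 percentage points lower from compound 2 to compound 3 (beyond the scatter) both lie beyond the scatter; compound 1 and compound 3 sit within the scatter of each other, as a number 1 percentage points lower from compound 1 to compound 3 (within the scatter) shows.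

Compound 4 `CCCCCCCCCCc1ccc(-c2noc(C(Cl)CCN)n2)cc1` differs from compound 2 by a group of 5 heavy atoms (3 carbon, 1 nitrogen, 1 chlorine; no ring) in place of a group of 5 heavy atoms (4 carbon, 1 nitrogen; one four-membered non-aromatic ring with 1 hetero atom), on an aromatic carbon. The change removes the four-membered ring and puts a group with no ring in its place. Within the data shown here, the steps that bear on it are the move from the 2-(methylamino)ethyl chain to the azetidin-3-yl ring, a number 18 percentage points higher from compound 1 to compound 2 (beyond the scatter), and the move from that ring to the larger pyrrolidin-3-yl ring, a number 19 percentage points lower from compound 2 to compound 3 (beyond the scatter). Both changes away from the azetidine lowered inhibition in this assay, so a fall is expected for compound 4, roughly back to the level of compound 1, as a number 23 percentage points lower from compound 2 to compound 4 (beyond the scatter). Among the measured compounds shown here, no chlorine-bearing analogue has been measured, so the estimate is uncertain; compound 4 is expected to give 40%, between 20% and 60%.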

Compound 4, a percentage reported as inhibition, at one concentration (the size of the read-out at that concentration, not a potency): 5%
Beside the measured number, compound 4's estimate is 35 percentage points above it; measured number below the stated range.
By their numbers in this assay, from the lowest: compound 4; then compounds 3 and 1 (each within the scatter of the next); then compound 2.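

In this assay the group with chlorine and no ring gives the largest steps seen at this position, a number 58 percentage points lower from compound 2 to compound 4 (beyond the scatter) and a number 39 percentage points lower from compound 3 to compound 4 (beyond the scatter). Losing the ring does not by itself account for this, as compound 1 also has no ring and the same count of 5 heavy atoms, yet the step is a number 40 percentage points lower from compound 1 to compound 4 (beyond the scatter); so at this position, groups of equal size without a ring can differ widely in inhibition. Nothing measured here gives a reason for the fall.

Going by these compounds, what a 3-aminopropyl group without the chlorine would give remains open, so the shares of the chlorine and of the primary amine in the fall cannot yet be separated. Also open, on these data alone, is whether a fluorine or a hydroxyl in place of the chlorine would give a similar number.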